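This account rests on a few compounds, and the source may have more. Where it says the series, first, only, none or still open, it means among the compounds named here.

Measured compounds:
Compound 1, `COc1cc(NS(=O)(=O)c2ccc(N3CCNC3=O)cc2)cc(OC)c1OC` — in a functional assay on CHO-TAX 5-6 cells (Cricetulus griseus) for antiproliferative activity, read by sulforhodamine B assay, with a stated time of 48 h (a higher number here means a weaker inhibitor, a lower number a stronger inhibitor), compound 1 gives 170 nM.
Compound 2, `COc1cccc(NS(=O)(=O)c2ccc(N3CCNC3=O)cc2)c1` — compound 2 gives 200 nM.
Compound 3, `Cc1cc(C)cc(NS(=O)(=O)c2ccc(N3CCNC3=O)cc2)c1` — compound 3 gives 120 nM.

Compound 3 has the lowest of the three numbers, but the gaps are small: compound 1 is the nearest, and a 1.7-fold lower number from compound 2 to compound 3 (0.22 log units; within the scatter) is the widest gap, so none of the three can be set apart from the others.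

Compound 4, `O=C1NCCN1c1ccc(S(=O)(=O)Nc2cccc(Cl)c2)cc1`, differs from compound 3 in one place: 3-chlorophenyl in place of 3,5-dimethylphenyl on a sulfonamide nitrogen. Among the measured compounds shown here, the one measured step at this position is a 1.7-fold lower number from compound 2 to compound 3 (0.22 log units; within the scatter), which swapped one group on the sulfonamide nitrogen for another and left the number within the scatter. For the measured compounds named here, no step with a 3-chlorophenyl group has been measured, so nothing beyond that single step bears on the change. The expectation is therefore a step of about a 1.3-fold higher number from compound 3 to compound 4 (0.10 log units; within the scatter), which would lie within the scatter, because a 1.7-fold lower number from compound 2 to compound 3 (0.22 log units; within the scatter) shows that the group on the sulfonamide nitrogen has so far moved the number little.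

For compound 4 the estimate in this assay is 150 nM, with a range from 60 nM to 400 nM.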

Compound 4, half-maximal inhibitory concentration: 58 nM
Compound 4: the middle estimate sits 2.6-fold (0.41 log units) above what was measured; the measured number lies below the stated range.
By their numbers in this assay, from the lowest: compound 4; then compounds 3, 1 and 2 (each within the scatter of the next).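

In this assay the group on the sulfonamide nitrogen can move the number beyond the scatter: with 3-chlorophenyl in place of 3,5-dimethylphenyl there is a 2.1-fold lower number from compound 3 to compound 4 (0.32 log units; beyond the scatter) and the earlier step at this position stayed within the scatter. Among the compounds shown here, the change of chloro in place of methoxy on an aromatic carbon gives a larger, though still modest, step, with a 3.4-fold lower number from compound 2 to compound 4 (0.54 log units; beyond the scatter) as the widest gap among the steps so far. Nothing available explains either step.

The step from 3,5-dimethylphenyl to 3-chlorophenyl swaps methyl for chloro and also leaves one group on the ring instead of two, so the compounds shown cannot tell these two differences apart, and a 3-methylphenyl group on the same nitrogen would be the direct test. Also open, on these data alone, is whether the lower number holds with other groups in the place of the chloro, such as bromo, trifluoromethyl, an amine or a carboxylic acid, and whether it carries over to any change in the shared core.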